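Pyrrolidine urea oxadiazoles: aryl swap at the assay limit

A few compounds are considered here, and "the series" means these few. Any claim that something is new, unique, unknown or untested is made for them only; others in the source may bear on it.

Compound 3 `Cc1cccc(-c2noc([C@@H]3CCCN3C(=O)Nc3ccc(Cl)cc3)n2)c1` stands in an ADME assay on MCF-10A cells (Homo sapiens) for inhibition, with a stated time of 48 h (on this read-out higher numbers stand for weaker inhibition and lower numbers for stronger inhibition), at a limit rather than a number: in this assay compound 3 gives > 50000 nM. Compound 1 `O=C(Nc1ccc(C(F)(F)F)cc1)N1CCC[C@H]1c1nc(-c2ccccc2)no1` sits at a limit in this assay as well, giving > 50000 nM. Compound 2 `O=C(Nc1ccc([N+](=O)[O-])cc1)N1CCC[C@H]1c1nc(-c2ccccc2)no1` likewise gives only a limit, > 50000 nM. For the measured compounds named here, the one step between measured compounds, a step that the two limits leave unreadable from compound 1 to compound 2, alters a different part of the shared core and cannot be read in size, so it says nothing about the exchange considered here. All three values sit at one and the same limit, (the limit of > 50000 nM in this assay, at which 3 of the 3 values shown sit). Compound 4 `O=C(Nc1ccc(Cl)cc1)N1CCC[C@H]1c1nc(-c2ccc(Br)cc2)no1` differs from compound 3 by 4-bromophenyl in place of 3-methylphenyl on an aromatic carbon. Going by the values given here, no measured step bears on this exchange, and there is no basis for expecting a shift beyond the scatter in either direction; the series so far lies entirely at the limit. Compound 4 is therefore expected to sit at or near the same limit, with a step that the limit leaves unreadable from compound 3 to compound 4 as the expected step. The estimate for compound 4 is 80000 nM, ranging from 20000 nM to 300000 nM.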

Compound 4, half-maximal inhibitory concentration: > 50000 nM
Compound 4 ended at the assay's limit (the forecaster's own chance of this, stated with the estimate: 80%); the middle value lies beyond the limit too.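

No step can be read from compound 3 to compound 4, as both stand at a limit rather than a number: the limit of > 50000 nM in this assay, at which 4 of the 4 values shown sit. The compounds shown leave open whether any exchange on the shared core shifts the read-out in this assay at all.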